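A few compounds are considered here, and "the series" means these few. Any claim that something is new, unique, unknown or untested is made for them only; others in the source may bear on it.

In an ADME assay on MT2 cells (Homo sapiens) for cytotoxicity (a higher number here means that more compound is tolerated, a lower number that less compound is tolerated), compound 3 `C/C=C/COc1cc(Nc2nccc(OC)n2)ccc1Cl` gives 17000 nM, the second highest of three numbers. Compound 2 `C/C=C/COc1cc(Nc2ncccn2)ccc1Cl` stands nearest with 31000 nM. The gap between them, a 1.8-fold lower number from compound 2 to compound 3 (0.26 log units; within the scatter), lies within the scatter. Compound 1 `CCc1ccnc(Nc2ccc(Cl)c(OCC=C(C)C)c2)n1` is furthest away with 330 nM. Compound 4 `COc1ccnc(Nc2ccc(Cl)c(Sc3ccccc3)c2)n1` has not yet been tested in this assay. The change is phenylsulfanyl in place of (but-2-en-1-yl)oxy on an aromatic carbon. Among the compounds with values here, no measured step matches this exchange: the single known step concerns methoxy for hydrogen at another place, and compound 1 differs from compound 3 in two places at once, so its number cannot be tied to one change. With no guide to direction, the step is expected to stay within the scatter, a 1.7-fold lower number from compound 3 to compound 4 (0.23 log units; within the scatter). Compound 4 is therefore estimated at 10000 nM, in a range from 2500 nM to 40000 nM.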

Compound 4, half-maximal cytotoxic concentration: 21000 nM
Estimate against measurement, compound 4: 2.1-fold (0.32 log units) below; measured number inside the range.
By their numbers in this assay, from the lowest: compound 1; then compounds 3, 4 and 2 (each within the scatter of the next).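

In this assay, putting phenylsulfanyl in place of (but-2-en-1-yl)oxy, ortho to the chloro group, gives a 1.2-fold higher number from compound 3 to compound 4 (0.09 log units; within the scatter) and so leaves the number unchanged within the scatter. At this position, then, an open chain with a double bond and a six-membered aromatic ring attached through sulfur read alike, although the two groups differ in shape and in their linking atom. Nothing measured here explains this result. Still open, on these data alone, is whether an amine or a carboxylic acid at this position would give a similar number, and whether phenyloxy would match phenylsulfanyl.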